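Chlorine position on the pendant phenyl of the series

The source may hold more compounds than are shown below. What is called first, only, known or untested is meant among the compounds shown, and "the series" means these compounds.

Compound 1 `COc1cc(-n2cnc3ccc(-c4cccc(N)c4)cc32)cc(OC)c1OC` gives 21 nM in a functional assay on SGC-7901 cells (Homo sapiens) for antiproliferative activity, read by MTT assay, with a stated time of 72 h; a higher number here means a weaker inhibitor, a lower number a stronger inhibitor. Compound 2 `COc1cc(-n2cnc3ccc(-c4ccc(Cl)cc4)cc32)cc(OC)c1OC` gives 1270 nM in this assay and stands second highest of the three numbers; compound 3 `COc1cc(-n2cnc3ccc(-c4cccc(C)c4C)cc32)cc(OC)c1OC` gives 3040 nM in this assay. The steps of a 60-fold higher number from compound 1 to compound 2 (1.78 log units; beyond the scatter) and a 140-fold higher number from compound 1 to compound 3 (2.16 log units; beyond the scatter) are large, whereas a 2.4-fold higher number from compound 2 to compound 3 (0.38 log units; beyond the scatter) is modest.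

Compound 4 `COc1cc(-n2cnc3ccc(-c4ccccc4Cl)cc32)cc(OC)c1OC` differs from compound 2 only on the pendant ring: 2-chlorophenyl in place of 4-chlorophenyl on an aromatic carbon. Within the data shown here, no measured step moves the chlorine around that ring, so no direct precedent exists. The nearest guide is a 2.4-fold higher number from compound 2 to compound 3 (0.38 log units; beyond the scatter), a modest step between two compounds that both lack the amine of compound 1, which suggests that changes among such rings stay modest. The expected step in this assay is therefore a 1.6-fold higher number from compound 2 to compound 4 (0.20 log units; within the scatter), of uncertain direction and within a wide range. Compound 4 is expected to give 2000 nM in this assay, with a range from 500 nM to 7000 nM.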

Compound 4, half-maximal inhibitory concentration: > 10000 nM
Compound 4: no number, only a limit; the forecaster's own chance of this, stated with the estimate: 5%; middle value at least 5.0-fold (0.69 log units) away from the limit.
By their numbers in this assay, from the lowest: compound 1; then compound 2; then compound 3. At a limit, above all of these: compound 4.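

Compound 4 gives a limit of the assay and not a number in this assay: the limit of > 10000 nM in this assay, at which 1 of the 4 values shown sits. Moving the chlorine alone, with the same atoms joined differently, is no neutral change on this ring, as shown by an at least 7.8-fold higher number from compound 2 to compound 4 (0.89 log units; beyond the scatter), so two rings without an amine can differ by more than the step between compound 2 and compound 3 had shown. The 2-chlorophenyl ring also falls behind 2,3-dimethylphenyl, with an at least 3.2-fold higher number from compound 3 to compound 4 (0.51 log units; beyond the scatter), and much further behind 3-aminophenyl, with an at least 470-fold higher number from compound 1 to compound 4 (2.67 log units; beyond the scatter), which makes compound 4 the weakest of the four.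

Going by these compounds, the full size of these steps stays unknown, since compound 4 has only a limit. On these data alone, whether a fluorine or a methyl group in place of that chlorine gives the same loss also stays open.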